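A few compounds are considered here, and "the series" means these few. Any claim that something is new, unique, unknown or untested is made for them only; others in the source may bear on it.

Of the compounds shown here, three sharing one core have been measured in an assay on isolated protein with metabotropic glutamate receptor 2 (Homo sapiens) as the target; a lower number here means that less compound is needed, a higher number that more compound is needed for the effect. Compound 1 `CCS(=O)(=O)N(Cc1cccnc1)c1cccc(C(=O)c2ccccc2)c1` carries a benzoyl group and gives 1100 nM. Compound 2 `C=C(c1ccccc1)c1cccc(N(Cc2cccnc2)S(=O)(=O)CC)c1` carries a 1-phenylethenyl group in its place and gives 200 nM. Compound 3 `CCS(=O)(=O)N(Cc1cccnc1)c1cccc(C(F)c2ccccc2)c1` carries a fluoro(phenyl)methyl group there and gives 180 nM. The step of a 6.1-fold lower number from compound 1 to compound 3 (0.79 log units; beyond the scatter) and the step of a 5.5-fold lower number from compound 1 to compound 2 (0.74 log units; beyond the scatter) are both modest, while the step of a 1.1-fold lower number from compound 2 to compound 3 (0.05 log units; within the scatter) stays within the scatter, so compound 3 and compound 2 stand together, and only compound 1 sits clearly apart.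

Compound 4 `CCS(=O)(=O)N(Cc1cccnc1)c1cccc(OC(F)(F)F)c1` makes a different kind of change: trifluoromethoxy in place of fluoro(phenyl)methyl on an aromatic carbon. Among the measured compounds shown here, every measured step kept a second aromatic ring at this position and only altered the link to it, so no step directly addresses removing that ring for a small group. The closest guide, the steps from compound 1, shows that changes here move the number by modest amounts. Compound 4 is therefore expected to give a higher number, with the step of a 5.0-fold higher number from compound 3 to compound 4 (0.70 log units; beyond the scatter) as the estimate, and compound 4 is expected at 900 nM within a range of 200 nM to 4000 nM.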

Compound 4, half-maximal effective concentration: 1600 nM
The estimate for compound 4 lay 1.8-fold (0.25 log units) below the measured number; the measured number falls inside the stated range.
By their numbers in this assay, from the lowest: compounds 3 and 2 (each within the scatter of the next); then compounds 1 and 4 (each within the scatter of the next).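

Trifluoromethoxy, which has no ring, does not match the two best groups at this position: the change gives an 8.9-fold higher number from compound 3 to compound 4 (0.95 log units; beyond the scatter) and an 8.0-fold higher number from compound 2 to compound 4 (0.90 log units; beyond the scatter) and these are the first steps here that remove the second aromatic ring. Yet a ring alone does not give a low number: compound 1 carries one too, and a 1.5-fold higher number from compound 1 to compound 4 (0.16 log units; within the scatter) places the ring-free trifluoromethoxy group and benzoyl together. Nothing measured here says why the numbers differ in this way. The compounds shown leave open how a small group of another kind, such as an amine or a carboxylic acid, would compare with trifluoromethoxy. They also leave open how a phenyl ring joined through a plain methylene link or an oxygen atom would compare with fluoro(phenyl)methyl and benzoyl.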